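Benzyl to pyridin-3-ylmethyl on a shared urea core

The source may report more compounds than this note shows. Statements on the series, on what has been measured and on what is new or still open speak of the compounds shown alone.

The measured compounds:
Compound 1, `CCCCn1c(SCc2cc([N+](=O)[O-])ccc2OC)nc2cc(NC(=O)NC(C)(C)C)ccc21`: 330 nM
Compound 2, `COc1ccc([N+](=O)[O-])cc1CSc1nc2cc(NC(=O)NC(C)(C)C)ccc2n1Cc1ccccc1`: 160 nM

Both were tested in an assay on isolated protein for inhibition of Gonadotropin-releasing hormone receptor (Rattus norvegicus); on this read-out lower numbers stand for stronger inhibition and higher numbers for weaker inhibition. Compound 1 gives 330 nM and compound 2 gives 160 nM, the lowest of the two numbers; the step of a 2.1-fold lower number from compound 1 to compound 2 (0.31 log units; beyond the scatter) lies beyond the scatter and is modest in size.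

Compound 3, `COc1ccc([N+](=O)[O-])cc1CSc1nc2cc(NC(=O)NC(C)(C)C)ccc2n1Cc1cccnc1`, has not yet been measured in this assay. It differs from compound 2 in one place: pyridin-3-yl in place of phenyl on a saturated chain carbon bound to an aromatic nitrogen. Going by the values given here, no measured step bears on this change; the single step seen, a 2.1-fold lower number from compound 1 to compound 2 (0.31 log units; beyond the scatter), concerns propyl against phenyl and says nothing about a ring nitrogen. With no evidence either way, the number for compound 3 in this assay is expected to stay close to that of compound 2, with a step of a 1.1-fold higher number from compound 2 to compound 3 (0.05 log units; within the scatter) that is estimated to lie within the scatter. Compound 3 is therefore expected to give about 180 nM, in a range from 70 nM to 450 nM.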

Compound 3, half-maximal inhibitory concentration: 150 nM
For compound 3 the middle estimate is 1.2-fold (0.08 log units) above the measured one; the range from low to high includes it.
By their numbers in this assay, from the lowest: compounds 3 and 2 (each within the scatter of the next); then compound 1.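

In this assay, the change from benzyl to (pyridin-3-yl)methyl gives a 1.1-fold lower number from compound 2 to compound 3 (0.03 log units; within the scatter), so at this place, on a saturated chain carbon bound to an aromatic nitrogen, a ring nitrogen and its hydrogen-bond acceptor are accommodated with no readable change in the number. Set against the propyl of compound 1, the pyridin-3-yl group gives a 2.2-fold lower number from compound 1 to compound 3 (0.34 log units; beyond the scatter), a modest step that matches in direction the one seen for phenyl, a 2.1-fold lower number from compound 1 to compound 2 (0.31 log units; beyond the scatter), so across these three compounds both aromatic rings give lower numbers than the propyl chain does. No measurement of any other kind is at hand to account for these numbers.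

The compounds shown leave open whether the ring nitrogen is tolerated only in this arrangement, since neither pyridin-2-yl nor pyridin-4-yl appears among them. They also leave open how far this place tolerates change on the ring itself, for instance a carboxylic acid or an amine on the pyridine or phenyl ring, and whether a longer chain between ring and core would keep the number.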